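The source may report more compounds than this note shows. Statements on the series, on what has been measured and on what is new or still open speak of the compounds shown alone.

Compound 1, `COc1ccc(-c2cc(/N=C3/NC(=O)CS3)cs2)cc1`, in a functional assay on HT-29 cells (Homo sapiens) for cytotoxicity, read by MTT assay, with a stated time of 72 h (on this read-out higher numbers stand for weaker inhibition and lower numbers for stronger inhibition), gives > 50000 nM, which is a limit of the assay rather than a number.
Compound 2, `O=C1CS/C(=N\c2csc(-c3ccccc3)c2)N1`, in this assay gives > 50000 nM, again a limit rather than a number.
Compound 3, `CN(C)c1ccc(/C=C2\S/C(=N\c3csc(-c4ccc(Cl)cc4)c3)NC2=O)cc1`, in this assay gives 1500 nM.

Among the measured compounds shown here, compound 3 therefore holds the only real number in this assay; the other two compounds sit at the limit of > 50000 nM in this assay, at which 2 of the 3 values shown sit, so their values can only be said to lie beyond what the assay resolves. For the measured compounds named here, the one step between measured compounds that differ in a single place, a step that the two limits leave unreadable from compound 1 to compound 2, cannot be sized for the same reason.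

Compound 4, `O=C1N/C(=N/c2csc(-c3ccc(Cl)cc3)c2)S/C1=C\c1ccccn1`, is compound 3 with pyridin-2-yl in place of 4-(dimethylamino)phenyl on a double-bonded chain carbon bound to a double-bonded ring carbon. Going by the values given here, no measured step touches this part of the molecule, and the single measured step concerns a different position and is itself unreadable, so nothing measured here bears on the change from compound 3 to compound 4. The step is therefore expected to be a 3.3-fold higher number from compound 3 to compound 4 (0.52 log units; beyond the scatter) in this assay, with no direction supported by the data and a wide range to reflect that. Compound 4 is estimated at 5000 nM in this assay, expected to fall between 1000 nM and 50000 nM.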

Compound 4, half-maximal inhibitory concentration: 11500 nM
Estimate against measurement, compound 4: 2.3-fold (0.36 log units) below; measured number inside the range.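

Among the compounds shown here, the swap of 4-(dimethylamino)phenyl for pyridin-2-yl on a double-bonded chain carbon bound to a double-bonded ring carbon gives the first step that can be sized in this assay: a 7.7-fold higher number from compound 3 to compound 4 (0.88 log units; beyond the scatter). This shows that the group at this place matters to the read-out, since the number moves beyond the usual scatter and towards weaker inhibition, while compound 4 still gives a real number and not a limit. Nothing measured here gives a reason for the step.

This single pair changes several things at once: the entering group has fewer heavy atoms than the leaving one, its ring holds a nitrogen, and the dimethylamino group is gone, so the compounds shown cannot say which of these differences carries the step. As far as these compounds go, whether the number depends on the ring nitrogen, on where it sits or on the amine stays open, and pyridin-3-yl or 4-aminophenyl at this same place would be the kind of group to separate those possibilities.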